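The source may report more compounds than this note shows. Statements on the series, on what has been measured and on what is new or still open speak of the compounds shown alone.

Of the compounds shown here, three sharing one core have been tested in an assay on isolated protein for binding affinity to corticotropin-releasing factor receptor 1 (Homo sapiens); a lower number here means a stronger inhibitor, a higher number a weaker inhibitor. Compound 1 `CC(=O)/C(=N\Nc1ccccc1C#N)N(C)c1cccc(Cl)c1` reaches only the limit of the assay, > 10000 nM. Compound 2 `CC(=O)/C(=N\c1cccc(Cl)c1)NNc1ccc(C)cc1` gives 2290 nM. Compound 3 `CSc1cccc(N/C(=N/Nc2ccccc2C)C(C)=O)c1` likewise returns only a limit, > 10000 nM. Compound 3 therefore sits at the limit of > 10000 nM in this assay, at which 2 of the 3 values shown sit, and its place among the three cannot be fixed any more closely. Compound 4 `CSc1cccc(N/C(=N/Nc2ccccc2C(F)(F)F)C(C)=O)c1` differs from compound 3 by trifluoromethyl in place of methyl on an aromatic carbon. Among the measured compounds shown here, no measured pair isolates this change, so the expected step from compound 3 to compound 4 in this assay is a step that the limit leaves unreadable from compound 3 to compound 4, nothing beyond the scatter in either direction. Compound 4 is accordingly estimated at 15000 nM, between 3000 nM and 60000 nM, and is expected most likely to be reported again only as a limit.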

Compound 4, inhibition constant: > 10000 nM
Compound 4: only a limit was reported; the forecaster's own chance of this, stated with the estimate: 70%; the middle value does not contradict the limit.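

Among the compounds shown here, compound 3 and compound 4 are both reported only as limits, so no step between them can be read: the limit of > 10000 nM in this assay, at which 3 of the 4 values shown sit. In this assay the compounds shown leave open whether trifluoromethyl in place of methyl on an aromatic carbon changes the inhibition constant at all.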